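This account rests on a few compounds, and the source may have more. Where it says the series, first, only, none or still open, it means among the compounds named here.

Values in an ADME assay on Huh-7 cells (Homo sapiens) for cytotoxicity, with a stated time of 72 h (on this read-out higher numbers stand for lower toxicity in this test and lower numbers for higher toxicity in this test), each one a limit and not a number:

- compound 1 `CC(C)CCn1nc(-c2cncs2)c(O)c(C2=NS(=O)(=O)c3cc(NS(C)(=O)=O)ccc3N2)c1=O` gives > 33000 nM
- compound 2 `CC(C)CCn1nc(CC(C)C)c(O)c(C2=NS(=O)(=O)c3cc(NS(C)(=O)=O)ccc3N2)c1=O` gives > 1000 nM
- compound 3 `CCC(C)(C)c1nn(CCC(C)C)c(=O)c(C2=NS(=O)(=O)c3cc(NS(C)(=O)=O)ccc3N2)c1O` gives > 1000 nM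

Compound 3 has only a limit, > 1000 nM. The series sits at two limits: the limit of > 1000 nM in this assay, at which 2 of the 3 values shown sit. The other is the limit of > 33000 nM in this assay, at which 1 of the 3 values shown sits.

Compound 4 `CC(C)CCc1nn(CCC(C)C)c(=O)c(C2=NS(=O)(=O)c3cc(NS(C)(=O)=O)ccc3N2)c1O` has not yet been measured in this assay. Its change from compound 3 is isopentyl in place of 1,1-dimethylpropyl on an aromatic carbon, ortho to a hydroxy group.

The closest measured change at this carbon is a step that the two limits leave unreadable from compound 2 to compound 3. Two more bear on it: a step that the two limits leave unreadable from compound 1 to compound 2 and a step that the two limits leave unreadable from compound 1 to compound 3. None of the three has a readable size. No size can be carried over from a step that the two limits leave unreadable from compound 2 to compound 3, so no direction is expected for compound 4.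

The expected change is a step that the limit leaves unreadable from compound 3 to compound 4, with no step beyond the scatter anticipated.

Compound 4 is estimated at 10000 nM, with an expected range from 1000 nM to 40000 nM, and a report as a limit is the likeliest outcome.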

Compound 4, half-maximal cytotoxic concentration: > 33000 nM
Compound 4 gave a limit, no number (the forecaster's own chance of this, stated with the estimate: 85%); at least 3.3-fold (0.51 log units) between middle value and limit.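

Compound 4 gives > 33000 nM, a limit and not a number. No step can be read between compound 4 and compounds 1, 2 or 3: all four values are limits. The compounds shown leave open whether these four differ at all in half-maximal cytotoxic concentration.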